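A few compounds are considered here, and "the series" means these few. Any claim that something is new, unique, unknown or untested is made for them only; others in the source may bear on it.

Of the compounds shown here, three built on one shared core have been tested in a functional assay on B16-F10 cells (Mus musculus) for inhibition, read by MTT assay, with a stated time of 48 h; a higher number here means a weaker inhibitor, a lower number a stronger inhibitor. Compound 1 `COc1ccc(/C=C/c2cc(OC)cc(OC)c2/C=C/C(=O)NC2CC2)cc1` gives 10200 nM, compound 2 `COc1ccc(/C=C/c2cc(OC)cc(OC)c2/C=C/C(=O)N2CCCCC2C)cc1` gives 7660 nM, and compound 3 `C#CCNC(=O)/C=C/c1c(/C=C/c2ccc(OC)cc2)cc(OC)cc1OC` gives 8280 nM. Compound 2 carries the lowest of the three numbers, yet the step of a 1.3-fold lower number from compound 1 to compound 2 (0.12 log units; within the scatter) and the step of a 1.1-fold higher number from compound 2 to compound 3 (0.03 log units; within the scatter) both fall within the scatter, as does a 1.2-fold lower number from compound 1 to compound 3 (0.09 log units; within the scatter), so the three compounds stand level rather than in any order.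

Compound 4 `COc1ccc(/C=C/c2cc(OC)cc(OC)c2/C=C/C(=O)N2CCCC(C)C2)cc1` differs from compound 2 at a single point, the carbonyl carbon: 3-methylpiperidin-1-yl in place of 2-methylpiperidin-1-yl on a carbonyl carbon. Within the data shown here, no measured step moves a methyl group from one position of a piperidine ring to another. The three steps that exist all exchange one amide substituent for another, and none of them leaves the scatter. On that ground one expects the step of a 1.0-fold lower number from compound 2 to compound 4 (0.01 log units; within the scatter) to stay within the scatter as well, with no clear direction. Compound 4 is therefore estimated at 7500 nM in this assay, with a range from 3500 nM to 16000 nM.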

Compound 4, half-maximal inhibitory concentration: 8250 nM
Compound 4: middle estimate off by 1.1-fold (0.04 log units), on the low side; the range from low to high includes it.
By their numbers in this assay, from the lowest: compounds 2, 4, 3 and 1 (each within the scatter of the next).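

In this assay, shifting the methyl group on the piperidine ring, from 2-methylpiperidin-1-yl to 3-methylpiperidin-1-yl on the carbonyl carbon, is now measured directly (a 1.1-fold higher number from compound 2 to compound 4 (0.03 log units; within the scatter)), and it stays within the scatter. Exchanging 3-methylpiperidin-1-yl for either of the other amide substituents also stays within the scatter (a 1.0-fold lower number from compound 3 to compound 4 (0.00 log units; within the scatter); a 1.2-fold lower number from compound 1 to compound 4 (0.09 log units; within the scatter)), so all four compounds stand level and neither the methyl position nor these amide substituents separate them here. Nothing available explains this flat picture.

The compounds shown leave open whether a group of a different kind on the carbonyl carbon, such as a carboxylic acid, an amine-bearing side chain or a longer alkyl chain, would move the number beyond the scatter. They also leave open whether the plain piperidin-1-yl group, without any methyl, would stand level with these four.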